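Swapping Bromo for Fluoro on the Triazole Aryl Group

This account rests on a few compounds, and the source may have more. Where it says the series, first, only, none or still open, it means among the compounds named here.

Compound 1 `C/C(=C\CC/C(C)=C/CC[C@@H]1[C@@]2(C)CCC(=O)C(C)(C)[C@H]2CC[C@@]1(C)O)CC/C=C(\C)C(=O)OCc1cn(-c2ccccc2Br)nn1`: in an ADME assay on L132 cells (Homo sapiens) for cytotoxicity, read by MTT assay, with a stated time of 48 h (a higher number here means a weaker inhibitor, a lower number a stronger inhibitor), compound 1 gives > 150000 nM, which is a limit of the assay and not a number.
Compound 2 `C/C(=C\CC/C(C)=C/CC[C@@H]1[C@@]2(C)CCC(=O)C(C)(C)[C@H]2CC[C@@]1(C)O)CC/C=C(\C)C(=O)OCc1cn(C[C@@H]2O[C@H](n3ccc(=O)[nH]c3=O)C[C@H]2O)nn1`: in this assay compound 2 gives 148000 nM.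
Compound 3 `C/C(=C\CC/C(C)=C/CC[C@@H]1[C@@]2(C)CCC(=O)C(C)(C)[C@H]2CC[C@@]1(C)O)CC/C=C(\C)C(=O)OCc1cn(-c2ccc(C)cc2)nn1`: in this assay compound 3 gives > 150000 nM, again a limit rather than a number.

Compound 1 thus stands at the boundary of what the assay can report, a position it shares with one other compound (the limit of > 150000 nM in this assay, at which 2 of the 3 values shown sit), while compound 2 sits near that boundary with a measured number. For the measured compounds named here, the only single-point comparison among the measured compounds, a step that the two limits leave unreadable from compound 1 to compound 3, cannot be sized because both of its ends are limits. Compound 4 `C/C(=C\CC/C(C)=C/CC[C@@H]1[C@@]2(C)CCC(=O)C(C)(C)[C@H]2CC[C@@]1(C)O)CC/C=C(\C)C(=O)OCc1cn(-c2ccccc2F)nn1` differs from compound 1 in one place: fluoro in place of bromo on an aromatic carbon. Going by the values given here, no measured step involves a halogen exchange; the one step that touches the aryl group on the triazole nitrogen is the unreadable one just mentioned. With every measured value at or near the limit, no movement beyond the usual scatter is expected in this assay. Compound 4 is estimated at 150000 nM, within 90000 nM to 300000 nM, and will most likely be reported as a limit once more. The expected step of a number no higher from compound 1 to compound 4 (the limit leaves the size open) amounts to essentially no change.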

Compound 4, half-maximal inhibitory concentration: > 150000 nM
Compound 4: a limit, no number; the forecaster's own chance of this, stated with the estimate: 75%; the middle value lies on the limit itself.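

In this assay compound 4 gives > 150000 nM, which is a limit of the assay and not a number. The steps to compound 4 from compound 1 and from compound 3 cannot be read, because all three compounds end at the same limit: the limit of > 150000 nM in this assay, at which 3 of the 4 values shown sit.

The compounds shown leave open whether changing the aryl group on the triazole moves the value at all.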